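Moving a carbon from isopropyl to propyl

This account rests on a few compounds, and the source may have more. Where it says the series, first, only, none or still open, it means among the compounds named here.

In a functional assay on the whole organism (strain Sprague-Dawley) with Rattus norvegicus as the target, in the maximal electroshock model (on this read-out higher numbers stand for an effect only at larger amounts of compound and lower numbers for an effect already at smaller amounts), compound 1, `CCCC(C(=O)NC(N)=O)C(C)C`, gives 16 mg/kg and stands lowest of the three numbers in hand. Its primary amide counterpart compound 2, `CCCC(C(N)=O)C(C)C`, gives 50 mg/kg in this assay, a change of a 3.1-fold higher number from compound 1 to compound 2 (0.49 log units; beyond the scatter) for hydrogen in place of carbamoyl on an amide-type nitrogen. For the measured compounds named here, the single stereoisomer compound 3, `CCC[C@@H](C(=O)NC(N)=O)C(C)C`, gives 36 mg/kg in this assay, which is a 2.3-fold higher number from compound 1 to compound 3 (0.35 log units; beyond the scatter); the difference between them lies only in the fact that one of compounds 1 and 3 is drawn with a defined configuration and the other without, at the place where they differ.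

Compound 4, `CCCC(CCC)C(=O)NC(N)=O`, differs from compound 1 by propyl in place of isopropyl on a saturated chain carbon bound to a carbonyl carbon and a saturated chain carbon. Neither measured step touches the side chain: one alters the acylurea head, the other only the drawn configuration. Both steps were modest and pointed toward larger doses, so a modest upward move is the expectation here too, though the evidence is indirect. The author therefore expects compound 4 to give 25 mg/kg in this assay, within 10 mg/kg to 60 mg/kg, a step of a 1.6-fold higher number from compound 1 to compound 4 (0.19 log units; within the scatter).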

Compound 4, dose for half-maximal effect in the Rattus norvegicus assay: 54 mg/kg
The estimate for compound 4 lay 2.2-fold (0.33 log units) below the measured number; low and high end bracket the measured number.
By their numbers in the Rattus norvegicus assay, from the lowest: compound 1; then compounds 3, 2 and 4 (each within the scatter of the next).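

For the compounds shown here, the earlier steps touched only the acylurea head and the drawn configuration, so in the Rattus norvegicus assay compound 4, which gives 54 mg/kg, is the first reading of the side chain itself. In the Rattus norvegicus assay, propyl in place of isopropyl gives a 3.4-fold higher number from compound 1 to compound 4 (0.53 log units; beyond the scatter) with the same atoms merely joined differently, which shows that the arrangement of the chain at this place counts on its own. In a physicochemical assay for solubility (on this read-out lower numbers stand for lower solubility and higher numbers for higher solubility), compound 1 gives 130 ug/mL and compound 4 gives 120 ug/mL; the same change gives a 1.1-fold lower number from compound 1 to compound 4 (0.03 log units; within the scatter) and so the two compounds part on one read-out only, while nothing in hand accounts for the step in the whole-animal numbers.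

Going by these compounds, whether a longer chain such as butyl, or a ring such as cyclopropyl, at this place would carry the numbers further remains open. So does whether the same change would give a similar step on the primary amide head of compound 2.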